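The source may report more compounds than this note shows. Statements on the series, on what has been measured and on what is new or still open speak of the compounds shown alone.

Measured compounds in a functional assay on PC-3 cells (Homo sapiens) for cytotoxicity, read by MTT assay, with a stated time of 72 h; a lower number here means a stronger inhibitor, a higher number a weaker inhibitor:
compound 1, `O=C(Nc1ccc(Oc2ccnc3[nH]ccc23)cc1)c1nn(-c2ccc(Cl)cc2)ccc1=O`, 32400 nM
compound 2, `O=C(Nc1ccc(Oc2ccnc3[nH]ccc23)cc1)c1nn(-c2ccc(Cl)c(C(F)(F)F)c2)ccc1=O`, 4630 nM
compound 3, `Cn1ccc2c(Oc3ccc(NC(=O)c4nn(-c5ccc(Cl)cc5)ccc4=O)cc3)ccnc21`

In this assay compound 3 gives only > 60000 nM, which is a limit of the assay and not a number. Among the three measured compounds, compound 3 is the one that stands only as a limit; the step of an at least 1.8-fold higher number from compound 1 to compound 3 (0.26 log units; that floor lies within the scatter) runs into (the limit of > 60000 nM in this assay, at which 1 of the 3 values shown sits).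

Compound 4, `Cn1ccc2c(Oc3ccc(NC(=O)c4nn(-c5ccc(Cl)c(F)c5)ccc4=O)cc3)ccnc21`, differs from compound 3 by fluoro in place of hydrogen on an aromatic carbon. Going by the values given here, the one measured step at that position is a 7.0-fold lower number from compound 1 to compound 2 (0.84 log units; beyond the scatter), where the entering group was trifluoromethyl rather than fluoro. Fluoro is not trifluoromethyl, and compound 3 starts from a limit, so for compound 4 a smaller step of an at least 1.7-fold lower number from compound 3 to compound 4 (0.23 log units; that floor lies within the scatter) toward a lower number is expected. The estimate for compound 4 in this assay is 35000 nM, range 12000 nM to 100000 nM.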

Compound 4, half-maximal inhibitory concentration: 32700 nM
Compound 4: the middle estimate sits 1.1-fold (0.03 log units) above what was measured; measured number inside the range.
By their numbers in this assay, from the lowest: compound 2; then compounds 1 and 4 (each within the scatter of the next). At a limit, above all of these: compound 3.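

In this assay, fluoro on the aromatic carbon ortho to the chloro group gives an at least 1.8-fold lower number from compound 3 to compound 4 (0.26 log units; that floor lies within the scatter). The true size of this step stays unreadable, since compound 3 stands at a limit: the limit of > 60000 nM in this assay, at which 1 of the 4 values shown sits. The position now carries fluoro as well as trifluoromethyl, and the number moves downward with the methyl on the aromatic nitrogen too.

Going by these compounds, how trifluoromethyl would act on compound 3, and fluoro on compound 1, remains open. So does the effect of a methoxy group or an amine at this position.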